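Swapping One Ether Side Chain for Its Isomer

The source may report more compounds than this note shows. Statements on the series, on what has been measured and on what is new or still open speak of the compounds shown alone.

In a functional assay on OCI-Ly3 cells (Homo sapiens) for antiproliferative activity (a lower number here means that less compound is needed, a higher number that more compound is needed for the effect), compound 2 `CCOC(C)c1c(NC(=O)Nc2cnc(-n3nccn3)c(Cl)c2)cnc2ccccc12` gives 1530 nM. Among the compounds with values here, compound 1 `O=C(Nc1cnc(-n2nccn2)c(Cl)c1)Nc1cnc2ccccc2c1C1CC1` gives 1580 nM, so the only two measured compounds stand level within the scatter.

Compound 3 `COC(C)(C)c1c(NC(=O)Nc2cnc(-n3nccn3)c(Cl)c2)cnc2ccccc12` keeps the same atoms but joins them differently, with 1-methoxy-1-methylethyl in place of 1-ethoxyethyl on an aromatic carbon.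

Within the data shown here, one measured step bears on this change. It swapped cyclopropyl for 1-ethoxyethyl on that same aromatic carbon, and it came to a 1.0-fold lower number from compound 1 to compound 2 (0.01 log units; within the scatter). That is a single step, and it says little about how an isomer of the side chain will behave. Still, it gives no reason to expect a clear shift in this assay, in either direction. The expected change is a 1.0-fold lower number from compound 2 to compound 3 (0.01 log units; within the scatter), which would stay within the scatter. Compound 3 is estimated at 1500 nM, with a likely range of 600 nM to 3500 nM.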

Compound 3, half-maximal effective concentration: 4430 nM
The estimate for compound 3 lay 3.0-fold (0.47 log units) below the measured number; measured number above the stated range.
By their numbers in this assay, from the lowest: compounds 2 and 1 (each within the scatter of the next); then compound 3.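

Up to this point, the position had shown no difference between the two side chains measured. In this assay the swap between isomers gives a 2.9-fold higher number from compound 2 to compound 3 (0.46 log units; beyond the scatter) and so shows that the same atoms, joined differently, can move the result beyond the scatter. The comparison with the cyclopropyl compound points the same way, with a 2.8-fold higher number from compound 1 to compound 3 (0.45 log units; beyond the scatter) and 1-methoxy-1-methylethyl as the one side chain of the three that needs more compound, though nothing available here accounts for the gap between the two isomers.

The compounds shown leave open how an amine or a carboxylic acid on this aromatic carbon would fare, and whether a longer ether chain would sit with compound 2 or with compound 3. From the compounds shown here alone, they also rest on this single assay, so whether the same order holds in any other test remains unknown.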